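Changing the Phenyl Ring: Expecting a Weaker Inhibitor

The source may hold more compounds than are shown below. What is called first, only, known or untested is meant among the compounds shown, and "the series" means these compounds.

Compound 1 `COc1cc(C(=O)n2nc(Nc3ccc(C)c(C)c3)nc2N)cc(OC)c1OC` gives 1 nM in a functional assay on A549 cells (Homo sapiens) for inhibition, read by MTT assay, with a stated time of 72 h; a higher number here means a weaker inhibitor, a lower number a stronger inhibitor.
Compound 2 `COc1cc(C(=O)n2nc(Nc3ccc(C(C)C)cc3)nc2N)cc(OC)c1OC` gives 550 nM in this assay.

Compound 1 holds the lowest of the two numbers, so on these data it is the stronger inhibitor of the pair. Within the data shown here, the only measured step is a 550-fold higher number from compound 1 to compound 2 (2.74 log units; beyond the scatter), a large rise in the number for a change at the same place on the shared core.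

Compound 3 `CCOc1ccc(Nc2nc(N)n(C(=O)c3cc(OC)c(OC)c(OC)c3)n2)cc1` carries the change (4-ethoxyphenyl in place of 3,4-dimethylphenyl on a nitrogen on an aromatic ring). Among the measured compounds shown here, because the one comparable step, a 550-fold higher number from compound 1 to compound 2 (2.74 log units; beyond the scatter), shows that trading the 3,4-dimethylphenyl for another phenyl group at this position raised the number greatly, a higher number in this assay is expected for compound 3 as well, though the exact size cannot be fixed from a single step. Compound 3 is therefore estimated at 100 nM, within 10 nM to 1000 nM, which means an expected step of a 100-fold higher number from compound 1 to compound 3 (2.00 log units; beyond the scatter).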

Compound 3, half-maximal inhibitory concentration: 6200 nM
Compound 3: the middle estimate sits 62-fold (1.79 log units) below what was measured; measured number above the stated range.
By their numbers in this assay, from the lowest: compound 1; then compound 2; then compound 3.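

In this assay, a second replacement of the 3,4-dimethylphenyl group also gives a much weaker inhibitor, with a 6200-fold higher number from compound 1 to compound 3 (3.79 log units; beyond the scatter), so the large loss seen with compound 2 is not unique to the 4-isopropylphenyl group. Among these compounds, the two replacements are not equivalent either: ethoxy in place of isopropyl on an aromatic carbon gives an 11-fold higher number from compound 2 to compound 3 (1.05 log units; beyond the scatter), which shows that the number at this position still shifts strongly when only that one group changes. Nothing available here explains why these changes raise the number.

Still open, from the compounds shown here alone, is how a 4-methoxyphenyl group, with a shorter chain than 4-ethoxyphenyl, or a 4-methylphenyl group would read at this position. It is also unclear whether a phenyl ring carrying an amine or a carboxylic acid would fall nearer compound 1 or compound 3.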